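From a propyl amide to a cyclopentyl amide

The compounds below may be only part of what the source reports. "The series", "measured", "known", "first", "only" and "open" are said of these compounds alone.

- compound 1 `CCCNC(=O)c1ccc2c(ccn2-c2ncc3c(n2)N(c2ccn(C)n2)C(CC)C(=O)N3C)c1`: 11000 nM
- compound 2 `CCC1C(=O)N(C)c2cnc(Nc3ccc(S(=O)(=O)NCCCO)cc3)nc2N1c1ccn(C)n1`: 25800 nM

In a functional assay on NCI-H1975 cells (Homo sapiens) for antiproliferative activity, read by CCK-8 assay, with a stated time of 72 h (a lower number here means a stronger inhibitor of growth, a higher number a weaker inhibitor of growth), compound 1 holds the lower of the two numbers, and compound 2 stands higher by more than the usual scatter. Compound 3 `CCC1C(=O)N(C)c2cnc(-n3ccc4cc(C(=O)NC5CCCC5)ccc43)nc2N1c1ccn(C)n1`, not yet measured, carries cyclopentyl in place of propyl on an amide-type nitrogen. Going by the values given here, no measured pair shows this kind of change, so the expectation rests on the structural change alone. The estimated step of a 1.2-fold lower number from compound 1 to compound 3 (0.09 log units; within the scatter) is expected to stay within the scatter, with no firm direction. Compound 3 is estimated at 9000 nM (expected range 3000 nM to 27000 nM).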

Compound 3, concentration for 50% growth inhibition: "not active" (no number reported)
Compound 3: no number reported; no gap can be computed for the estimate.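

In this assay, going by these compounds alone, compound 3 is reported as "not active" without a number, so no step from compound 1 to compound 3 can be read. Nothing available bears on this result. The compounds shown leave open how cyclopentyl in place of propyl shifts growth inhibition in numerical terms.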